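From 3-(dimethylamino)propyl to 4-(dimethylamino)butyl on compound 2

A few compounds are considered here, and "the series" means these few. Any claim that something is new, unique, unknown or untested is made for them only; others in the source may bear on it.

Among the measured compounds shown here, in a functional assay on HL-60 cells (Homo sapiens) for antiproliferative activity, read by MTT assay, with a stated time of 48 h (a lower number here means a stronger inhibitor, a higher number a weaker inhibitor), only two compounds have been measured so far. Compound 1 (`CN(C)CCCCn1c(N)c(C#N)c2nc(C#N)c(C#N)nc21`) gives 12900 nM, and compound 2 (`CN(C)CCCn1c(N)c(-c2nc3ccccc3n2C)c2nc(C#N)c(C#N)nc21`) gives 2120 nM. Compound 2 therefore holds the lower of the two numbers, and the gap between them lies beyond the scatter. The two compounds differ in more than one place, so this gap cannot be assigned to any single change.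

Compound 3 (`CN(C)CCCCn1c(N)c(-c2nc3ccccc3n2C)c2nc(C#N)c(C#N)nc21`) has not yet been measured. It departs from compound 2 only in the side chain: (dimethylamino)methyl in place of dimethylamino on a saturated chain carbon, three bonds along the chain from an aromatic nitrogen. Cut one bond further out, the same change reads 3-(dimethylamino)propyl to 4-(dimethylamino)butyl. Compound 3 thus pairs the chain of compound 1 with the remainder of compound 2. For the measured compounds named here, no measured pair shows the effect of this chain change alone, so the expectation is a cautious one. In this assay, the expected step of a 1.1-fold higher number from compound 2 to compound 3 (0.04 log units; within the scatter) is none beyond the scatter, with no firm direction. Compound 3 is estimated at 2300 nM, with an expected range from 1000 nM to 5500 nM.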

Compound 3, half-maximal inhibitory concentration: 740 nM
Estimate against measurement, compound 3: 3.1-fold (0.49 log units) above, outside the stated range (below it).
By their numbers in this assay, from the lowest: compound 3; then compound 2; then compound 1.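

In this assay, going from 3-(dimethylamino)propyl to 4-(dimethylamino)butyl gives a 2.9-fold lower number from compound 2 to compound 3 (0.46 log units; beyond the scatter), the only reading shown of this chain change on its own, and it shows that the added chain carbon alters the result by more than the usual scatter, in favour of the longer chain. With the 4-(dimethylamino)butyl chain held fixed, compound 3 also isolates the other difference: 1-methyl-1H-benzimidazol-2-yl in place of cyano on an aromatic carbon gives a 17-fold lower number from compound 1 to compound 3 (1.24 log units; beyond the scatter), which is large, whereas the chain step is modest. Nothing available accounts for either step.

With only two chain lengths on this core, the compounds shown leave open whether a 5-(dimethylamino)pentyl chain would lower the number further or reverse the direction, and whether a piperidine in place of the dimethylamino group would preserve the gain. They also leave open whether the chain step would hold with cyano in place of 1-methyl-1H-benzimidazol-2-yl, and whether another group at that aromatic carbon, such as an unmethylated benzimidazole, would match the large step.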